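The compounds below may be only part of what the source reports. "The series", "measured", "known", "first", "only" and "open" are said of these compounds alone.

Measured compounds:
- Compound 1 `Cc1cc(NC(=O)Nc2ccc(C)c(Cl)c2)c2ccccc2n1`; in an ADME assay on HEK293 cells (Homo sapiens) for cytotoxicity, with a stated time of 72 h (on this read-out higher numbers stand for an effect only at larger amounts of compound and lower numbers for an effect already at smaller amounts), compound 1 gives > 25000 nM, which is a limit of the assay and not a number.
- Compound 2 `COc1ccc(NC(=O)Nc2cc(C)nc3ccccc23)cc1Cl`; compound 2 gives 26000 nM.
- Compound 3 `Cc1cc(NC(=O)Nc2cccc(Cl)c2)c2ccccc2n1`; compound 3 gives 21000 nM.

Of the two numbers shown, that of compound 2 is the larger, but the gap to its nearest neighbour is only a 1.2-fold lower number from compound 2 to compound 3 (0.09 log units; within the scatter), so the two cannot be told apart. The step of an at least 1.1-fold lower number from compound 1 to compound 3 (0.07 log units; that floor lies within the scatter) is likewise within the scatter, and the step that the limit leaves unreadable from compound 1 to compound 2 cannot be read because of the limit of > 25000 nM in this assay, at which 1 of the 3 values shown sits.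

Compound 4 `COc1ccc(NC(=O)Nc2cc(C)nc3ccccc23)cc1` differs from compound 2 by hydrogen in place of chloro on an aromatic carbon. Going by the values given here, no measured step removes a chloro group, so the change is judged only by analogy with the other single changes on the same ring, each of which left the read-out within the scatter. The step from compound 2 to compound 4 is therefore expected to be a 1.0-fold lower number from compound 2 to compound 4 (0.02 log units; within the scatter), that is, nothing beyond the scatter in either direction. For compound 4 the estimate is 25000 nM, with a range from 12000 nM to 50000 nM, and a fair chance that only a limit is reported.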

Compound 4, half-maximal effective concentration: > 25000 nM
Compound 4: a limit, no number; the forecaster's own chance of this, stated with the estimate: 40%; the middle value lies on the limit itself.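

Compound 4 gives > 25000 nM in this assay as a limit and not a number, so the step between compound 2 and compound 4 cannot be read: the limit of > 25000 nM in this assay, at which 2 of the 4 values shown sit. The compounds shown leave open whether hydrogen in place of chloro changes the read-out at all, and in which direction.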